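The source may hold more compounds than are shown below. What is called first, only, known or untested is meant among the compounds shown, and "the series" means these compounds.

Compound 1 `CCCCNc1nc(NCc2ccccc2)c2ccccc2n1` gives 5100 nM in an ADME assay on J774.A1 cells (Mus musculus) for cytotoxicity, read by MTT assay, with a stated time of 72 h; a lower number here means that less compound is needed, a higher number that more compound is needed for the effect.
Compound 2 `c1ccc(CNc2nc(Nc3ccccc3)nc3ccccc23)cc1` gives 6800 nM in this assay.
Compound 3 `CCCCNc1nc(NCc2ccccc2)nc2ccccc12` gives 4900 nM in this assay.

Compound 1 and compound 2 share a core and differ by one change, (phenyl in place of butyl on a nitrogen on an aromatic ring); that change made the step of a 1.3-fold higher number from compound 1 to compound 2 (0.12 log units; within the scatter). Compound 3 is built on a different core; how the two cores differ is not broken down here. Compound 4 `c1ccc(CNc2nc(Nc3ccccc3)c3ccccc3n2)cc1` has not yet been measured; it stands to compound 3 as compound 2 stands to compound 1, through the same change, (phenyl in place of butyl on a nitrogen on an aromatic ring). The account rests on a single measured pair, so the expectation for compound 4 carries real uncertainty. The step expected from compound 3 to compound 4 in this assay is a 1.3-fold higher number from compound 3 to compound 4 (0.12 log units; within the scatter), resting on the step seen from compound 1 to compound 2, a 1.3-fold higher number from compound 1 to compound 2 (0.12 log units; within the scatter). Compound 4 is therefore estimated at 6500 nM, with a likely range from 3500 nM to 12000 nM.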

Compound 4, half-maximal effective concentration in the J774.A1 assay: 5200 nM
Estimate against measurement, compound 4: 1.3-fold (0.10 log units) above; low and high end bracket the measured number.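

In the J774.A1 assay the change from butylamino to anilino gave a 1.1-fold higher number from compound 3 to compound 4 (0.03 log units; within the scatter) and, set beside the step on the other core, it does not differ: the same change on two cores in the J774.A1 assay, a 1.3-fold higher number (0.12 log units; within the scatter) from compound 1 to compound 2 and a 1.1-fold higher number (0.03 log units; within the scatter) from compound 3 to compound 4, 1.3-fold (0.10 log units) apart, within the scatter of two such steps. The change thus carried from one core to the other without a step beyond the scatter, but since neither step stands out from the scatter, this does not show that a larger effect would carry across, and two cores make no rule for the series. In a physicochemical assay for lipophilicity, at pH 7.4 (a higher number here means a more lipophilic compound, a lower number a more polar compound), compound 3 gives 3.84 and compound 4 gives 4.25, so the same pair did separate: the measured distribution coefficient of compound 3, 3.84, and of compound 4, 4.25, a number 0.41 log units higher (beyond the scatter).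

The compounds shown leave open whether the pattern would hold with other groups on that nitrogen, such as a longer chain, a cyclohexyl ring or a pyridyl ring. They also leave open whether it would hold on a third core.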